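Trimming the chain of compound 3 to but-1-en-1-yl

This account rests on a few compounds, and the source may have more. Where it says the series, first, only, none or still open, it means among the compounds named here.

In a functional assay on KYSE-450 cells (Homo sapiens) for inhibition, read by MTT assay, with a stated time of 48 h (on this read-out higher numbers stand for weaker inhibition and lower numbers for stronger inhibition), compound 1 `COc1ccc(CN(C(C)=O)c2cc(OC)c(OC)c(OC)c2)cc1O` gives 160 nM with methyl on the carbonyl carbon. Compound 2 `C#CC(=O)N(Cc1ccc(OC)c(O)c1)c1cc(OC)c(OC)c(OC)c1` gives 570 nM with ethynyl there, and compound 3 `C/C=C/C=C/C(=O)N(Cc1ccc(OC)c(O)c1)c1cc(OC)c(OC)c(OC)c1` gives 180 nM with penta-1,3-dien-1-yl. Compound 3 thus stands level with compound 1 within the scatter and clear of compound 2.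

Compound 4 `CC/C=C/C(=O)N(Cc1ccc(OC)c(O)c1)c1cc(OC)c(OC)c(OC)c1` differs from compound 3 in one place: ethyl in place of prop-1-en-1-yl on a double-bonded chain carbon bound to a double-bonded chain carbon so that but-1-en-1-yl now sits on the carbonyl. Within the data shown here, no measured compound tests this exact change. The nearest evidence is the swap of methyl for penta-1,3-dien-1-yl, which gives a 1.1-fold higher number from compound 1 to compound 3 (0.05 log units; within the scatter) and so shows no change. Only ethynyl stands apart, with a 3.6-fold higher number from compound 1 to compound 2 (0.55 log units; beyond the scatter) and a 3.2-fold lower number from compound 2 to compound 3 (0.50 log units; beyond the scatter) as modest steps. But-1-en-1-yl is expected to read with methyl and penta-1,3-dien-1-yl rather than with ethynyl.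

The expected step is a 1.1-fold higher number from compound 3 to compound 4 (0.05 log units; within the scatter) and no shift beyond the scatter is expected. Compound 4 is estimated at 200 nM with an expected range from 90 nM to 450 nM in this assay as the working figure.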

Compound 4, half-maximal inhibitory concentration: 72 nM
The estimate for compound 4 lay 2.8-fold (0.44 log units) above the measured number; the measured number lies below the stated range.
By their numbers in this assay, from the lowest: compound 4; then compounds 1 and 3 (each within the scatter of the next); then compound 2.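

In this assay, among these compounds, the group on the carbonyl proves more sensitive than the earlier compounds suggested: ethyl in place of prop-1-en-1-yl on a double-bonded chain carbon bound to a double-bonded chain carbon gives a 2.5-fold lower number from compound 3 to compound 4 (0.40 log units; beyond the scatter) and so separates two chains that might have been expected to read alike. But-1-en-1-yl also stands clear of methyl, with a 2.2-fold lower number from compound 1 to compound 4 (0.35 log units; beyond the scatter) on that step, and of ethynyl, with a 7.9-fold lower number from compound 2 to compound 4 (0.90 log units; beyond the scatter) on that step, which makes compound 4 the most potent of the four and shows no steady trend with chain size across methyl, but-1-en-1-yl and penta-1,3-dien-1-yl. Nothing measured here explains this gain.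

Open, on these data alone, is how a saturated butyl chain or a longer hex-1-en-1-yl chain would read on this carbonyl. A chain carrying an amine is equally untested among the compounds shown.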